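Piperidine series: replacing the amide with an aromatic heterocycle

The source may hold more compounds than are shown below. What is called first, only, known or untested is meant among the compounds shown, and "the series" means these compounds.

Compound 1 (`CCN1CC(NC(=O)[C@@H]2CCCN(S(=O)(=O)c3ccc(S(=O)(=O)N(CC)CC)cc3)C2)C1`) reaches only the limit (the limit of > 30000 nM in this assay, at which 1 of the 3 values shown sits); in a functional assay on MIA PaCa-2 cells (Homo sapiens) for inhibition, read by MTT assay, with a stated time of 7 days (on this read-out higher numbers stand for weaker inhibition and lower numbers for stronger inhibition), compound 1 gives > 30000 nM, a limit rather than a number. Compound 2 (`CCN(CC)S(=O)(=O)c1ccc(S(=O)(=O)N2CCC[C@@H](C(=O)NC3COC3)C2)cc1`) gives 2300 nM, and compound 3 (`CCN(CC)S(=O)(=O)c1ccc(S(=O)(=O)N2CCC[C@@H](C(=O)NC)C2)cc1`) gives 8600 nM. The steps are an at least 13-fold lower number from compound 1 to compound 2 (1.11 log units; beyond the scatter), an at least 3.4-fold lower number from compound 1 to compound 3 (0.54 log units; beyond the scatter) and a 3.7-fold higher number from compound 2 to compound 3 (0.57 log units; beyond the scatter). Compound 3 thus stands highest of the two numbers shown, nearest to compound 2.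

Compound 4 (`CCN(CC)S(=O)(=O)c1ccc(S(=O)(=O)N2CCC[C@@H](c3cc(C)no3)C2)cc1`) differs from compound 3 by 3-methyl-1,2-oxazol-5-yl in place of methylcarbamoyl on a saturated ring carbon. Among the compounds with values here, all three measured steps vary only the group on the amide nitrogen; none removes the carbonyl itself, so no measured step bears on this change. No direction is therefore expected with confidence. Compound 4 is estimated at 5000 nM, within 1000 nM to 30000 nM. That estimate means an expected 1.7-fold lower number from compound 3 to compound 4 (0.24 log units; within the scatter).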

Compound 4, half-maximal inhibitory concentration: 4900 nM
Estimate against measurement, compound 4: 1.0-fold (0.01 log units) above; the measured number falls inside the stated range.
By their numbers in this assay, from the lowest: compound 2; then compounds 4 and 3 (each within the scatter of the next). At a limit, above all of these: compound 1.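

In this assay, the carbonyl and amide hydrogen of methylcarbamoyl are not needed to hold the number at this saturated ring carbon, with 3-methyl-1,2-oxazol-5-yl in their place: a 1.8-fold lower number from compound 3 to compound 4 (0.24 log units; within the scatter). The (oxetan-3-yl)carbamoyl group keeps a modest edge over the aromatic ring: a 2.1-fold higher number from compound 2 to compound 4 (0.33 log units; beyond the scatter). With the (1-ethylazetidin-3-yl)carbamoyl group, an at least 6.1-fold lower number from compound 1 to compound 4 (0.78 log units; beyond the scatter) is a bound and not a measured size, as one end is a limit: the limit of > 30000 nM in this assay, at which 1 of the 4 values shown sits.

Open, going by these compounds, is whether the methyl on the aromatic ring contributes, as against an unsubstituted 1,2-oxazol-5-yl. Also open, on these data alone, is how a pyridine ring or a carboxylic acid would read at this ring carbon.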